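Isopropyl for carboxyethyl on a second benzimidazole core

The source may hold more compounds than are shown below. What is called first, only, known or untested is meant among the compounds shown, and "the series" means these compounds.

Measured compounds:
compound 1 `CC(=N)N1CCC(Oc2ccc3nc(C(C)C)n(Cc4ccc5ccc(C(=N)N)cc5c4)c3c2)CC1`: 5.7 nM
compound 2 `CC(=N)N1CCC(Oc2ccc3c(c2)nc(CCC(=O)O)n3Cc2ccc3ccc(C(=N)N)cc3c2)CC1`: 14 nM
compound 3 `CC(=N)N1CCC(Oc2ccc3nc(CCC(=O)O)n(Cc4ccc5ccc(C(=N)N)cc5c4)c3c2)CC1`: 18 nM

Of the compounds shown here, three have been tested in an assay on isolated protein for inhibition of serine protease 1 (Bos taurus); on this read-out lower numbers stand for stronger inhibition and higher numbers for weaker inhibition. Compound 1 gives 5.7 nM, compound 2 gives 14 nM and compound 3 gives 18 nM in this assay.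

Compounds 1 and 3 share one core and differ in a single place: isopropyl in place of 2-carboxyethyl on an aromatic carbon. This change gave a 3.2-fold lower number from compound 3 to compound 1 (0.50 log units; beyond the scatter), a step beyond the scatter.

Compound 2 and compound 3 are built from the same atoms joined differently; the difference between the two cores is not broken down here. Their values in this assay lie within the scatter of one another, so no order between them can be stated. Compound 1 sits clearly lower than compound 2.

The unmeasured compound 4 `CC(=N)N1CCC(Oc2ccc3c(c2)nc(C(C)C)n3Cc2ccc3ccc(C(=N)N)cc3c2)CC1` is related to compound 2 by isopropyl in place of 2-carboxyethyl on an aromatic carbon. The place of this change is described in the same words as for the step from compound 3 to compound 1, so it is the same change, now carried out on the core of compound 2.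

Going by the values given here, the expectation for compound 4 rests on the single earlier example: because a 3.2-fold lower number from compound 3 to compound 1 (0.50 log units; beyond the scatter) was seen on the other core, a step of about a 3.1-fold lower number from compound 2 to compound 4 (0.49 log units; beyond the scatter) is estimated in this assay, with some allowance for the cores not being identical. Compound 4 is therefore expected to give about 4.5 nM in this assay, with a likely range from 2 nM to 11 nM.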

Compound 4, inhibition constant: 16 nM
Estimate against measurement, compound 4: 3.6-fold (0.55 log units) below, outside the stated range (above it).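

In this assay, isopropyl in place of 2-carboxyethyl on the core of compound 2 gives a 1.1-fold higher number from compound 2 to compound 4 (0.06 log units; within the scatter), so on this core the two groups cannot be told apart on this read-out. Set beside the earlier step, the same change does not behave alike on the two cores: the same change on two cores in this assay, a 3.2-fold lower number (0.50 log units; beyond the scatter) from compound 3 to compound 1 and a 1.1-fold higher number (0.06 log units; within the scatter) from compound 2 to compound 4, 3.6-fold (0.56 log units) apart, beyond the scatter of two such steps. This shows that the step seen on the core of compound 1 cannot be carried to the core of compound 2 as a fixed amount, but two pairs do not show why the cores part ways, nor which of the two steps would be the more typical on any further core.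

The compounds shown leave open whether the two cores would also part ways with other groups on this aromatic carbon, such as a methyl group, a plain propyl chain, an amine or a longer chain ending in a carboxylic acid. They also leave open whether the gap depends on the acid end of the 2-carboxyethyl chain, which an amide or an ester at the end of that chain on both cores could help to settle.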